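Branching the alkyl chain on the fluorinated core

A few compounds are considered here, and "the series" means these few. Any claim that something is new, unique, unknown or untested is made for them only; others in the source may bear on it.

Measured so far in a functional assay on MCF7 cells (Homo sapiens) for cytotoxicity; a higher number here means that more compound is needed for the effect, a lower number that less compound is needed:
- compound 1 `COc1cc(Cc2nc3c(N)ncnc3n2CCCCCO)cc(OC)c1OC` gives 84900000 nM
- compound 2 `COc1cc(Cc2nc3c(N)ncnc3n2CC(C)CCCO)cc(OC)c1OC` gives 8770000 nM
- compound 3 `CCCCn1c(Cc2cc(OC)c(OC)c(OC)c2)nc2c(N)nc(F)nc21` gives 185000000 nM

Compound 3 stands at the highest of the three numbers in this assay. Its nearest neighbour is compound 1, whose number is lower by a gap beyond the scatter; the furthest is compound 2, whose number is lower still.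

Compound 4 `CC[C@H](C)Cn1c(Cc2cc(OC)c(OC)c(OC)c2)nc2c(N)nc(F)nc21` is the next member. It differs from compound 3 by methyl in place of hydrogen on a saturated chain carbon bound to two saturated chain carbons.

Among the measured compounds shown here, one measured step bears directly on this change: a 9.7-fold lower number from compound 1 to compound 2 (0.99 log units; beyond the scatter), the same substitution made on the chain of compound 1. That pair carries a different chain end and a different core from the pair of compound 3 and compound 4, so it is a single precedent and is followed with caution, but in direction it points clearly to a lower number.

The step from compound 3 to compound 4 is therefore expected to lower the number, estimated at a 6.2-fold lower number from compound 3 to compound 4 (0.79 log units; beyond the scatter). Compound 4 is expected to give about 30000000 nM in this assay, with a range of 6000000 nM to 150000000 nM.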

Compound 4, half-maximal effective concentration: 66700000 nM
Estimate against measurement, compound 4: 2.2-fold (0.35 log units) below; low and high end bracket the measured number.
By their numbers in this assay, from the lowest: compound 2; then compounds 4 and 1 (each within the scatter of the next); then compound 3.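

In this assay, methyl in place of hydrogen on a saturated chain carbon bound to two saturated chain carbons now also lowers the number on a second core, with a 2.8-fold lower number from compound 3 to compound 4 (0.44 log units; beyond the scatter). The direction thus holds in both available pairs, but the size does not carry over from one pair to the other: the same change on two cores in this assay, a 9.7-fold lower number (0.99 log units; beyond the scatter) from compound 1 to compound 2 and a 2.8-fold lower number (0.44 log units; beyond the scatter) from compound 3 to compound 4, 3.5-fold (0.54 log units) apart, beyond the scatter of two such steps The two pairs differ in chain end as well as in core, and the gap cannot be assigned to either difference alone.

Still open, on these data alone, is whether the step on a hydroxyl-ended chain keeps its size on the core of compound 3. Also open, as far as these compounds go, is how an ethyl group or an amine on this same carbon compares with methyl, and whether the mirror-image arrangement of the methyl in compound 4 gives a similar number.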